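The source may hold more compounds than are shown below. What is called first, only, known or untested is meant among the compounds shown, and "the series" means these compounds.

Compound 3 `CN(C)c1ncnc2c1ncn2Cc1ccc([N+](=O)[O-])cc1` stands with compound 1 `Cc1ccc(Cn2cnc3c(N(C)C)ncnc32)cc1` at the low end of the three numbers in a functional assay on the whole organism for inhibition, with Rattus norvegicus as the target, in the maximal electroshock model, at a dose of 25 mg/kg by the intraperitoneal route; on this read-out lower numbers stand for less inhibition and higher numbers for more inhibition at the one dose given (going by the name of the read-out): compound 3 gives 0%, compound 1 gives 0%, and compound 2 `CN(C)c1ncnc2c1ncn2Cc1ccc(F)cc1` gives 33%. Compound 4 `CN(C)c1ncnc2c1ncn2Cc1ccc(O)cc1` differs from compound 3 by hydroxy in place of nitro on an aromatic carbon. Two measured steps change the same aromatic carbon: no change at the digits printed from compound 1 to compound 3 (within the scatter), and a number 33 percentage points lower from compound 2 to compound 3 (beyond the scatter); the step of a number 33 percentage points higher from compound 1 to compound 2 (beyond the scatter) shows that this carbon can move the read-out. Among the compounds with values here, no measured step brings in a hydroxy group, so no direction is fixed from the data. The expected step for compound 4 in this assay is a number 10 percentage points higher from compound 3 to compound 4 (within the scatter), at most a small rise. Compound 4 is therefore estimated at 10% in this assay, with a range from 0% to 35%.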

Compound 4, a percentage reported as inhibition, in the whole organism at one dose (the size of the read-out at that dose, not a potency): 0%
Beside the measured number, compound 4's estimate is 10 percentage points above it; low and high end bracket the measured number.
By their numbers in this assay, from the lowest: compounds 1, 3 and 4 (each within the scatter of the next); then compound 2.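

In this assay, hydroxy on this aromatic carbon gives no change at the digits printed from compound 3 to compound 4 (within the scatter) and no change at the digits printed from compound 1 to compound 4 (within the scatter), while a number 33 percentage points lower from compound 2 to compound 4 (beyond the scatter). Among the four groups at this place, fluoro alone stands beyond the scatter of the others, and hydroxy, the only one with a hydrogen-bond donor, reads level with methyl and nitro. No evidence at hand explains this pattern. On these data alone, whether the fluoro result extends to chloro or bromo at this carbon remains open. As far as these compounds go, how an amine or a methoxy group would read here also remains open.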